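Fluoro added to a pendant phenyl in a cytotoxicity series

The source may report more compounds than this note shows. Statements on the series, on what has been measured and on what is new or still open speak of the compounds shown alone.

Compound 1: `COc1cc2c(Oc3ccc(NC(=O)c4nn(-c5ccccc5F)c(=O)c5ccccc45)cc3F)ccnc2cc1OCCCN1CCN(C)CC1` — 1050 nM
Compound 2: `COc1cc2c(Oc3ccc(NC(=O)c4nn(-c5ccccc5)c(=O)c5ccccc45)cc3F)ccnc2cc1OCCCN1CCCCC1` — 1880 nM

Of the compounds shown here, two have been measured in a functional assay on MDA-MB-231 cells (Homo sapiens) for cytotoxicity, read by MTT assay, with a stated time of 72 h; on this read-out higher numbers stand for weaker inhibition and lower numbers for stronger inhibition. Compound 1 gives 1050 nM and compound 2 gives 1880 nM; the two numbers lie within the usual scatter of each other, so neither can be set apart from the other. No single change between them is isolated, as the two differ in two places at once.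

Compound 3, `COc1cc2c(Oc3ccc(NC(=O)c4nn(-c5ccccc5F)c(=O)c5ccccc45)cc3F)ccnc2cc1OCCCN1CCCCC1`, differs from compound 2 by one change: fluoro in place of hydrogen on an aromatic carbon. For the measured compounds named here, no measured pair shows this change alone, so the step is estimated to be small, expected to stay within the scatter, with a slight lean toward a lower number, as compound 1, which carries the 2-fluorophenyl, gives 1050 nM. Compound 3 is expected to give 1400 nM, between 600 nM and 3500 nM, an expected step of a 1.3-fold lower number from compound 2 to compound 3 (0.13 log units; within the scatter).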

Compound 3, half-maximal inhibitory concentration: 910 nM
Beside the measured number, compound 3's estimate is 1.5-fold (0.19 log units) above it; the measured number falls inside the stated range.
By their numbers in this assay, from the lowest: compounds 3, 1 and 2 (each within the scatter of the next, the first and the last beyond it).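

In this assay, phenyl to 2-fluorophenyl now stands as a single change, ortho to a large group, and it gives a modest step beyond the scatter (a 2.1-fold lower number from compound 2 to compound 3 (0.32 log units; beyond the scatter)). Piperidin-1-yl in place of 4-methylpiperazin-1-yl on the chain stays within the scatter (a 1.2-fold lower number from compound 1 to compound 3 (0.06 log units; within the scatter)), so the fluorinated pair does not separate these two end groups. Nothing measured here accounts for the fluoro step. As far as these compounds go, whether chloro or methoxy at this place would give a similar step remains open. So does whether fluoro gives the same step when 4-methylpiperazin-1-yl ends the chain.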